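Lipophilicity notes on a four-compound series

The compounds below may be only part of what the source reports. "The series", "measured", "known", "first", "only" and "open" are said of these compounds alone.

Measured in a physicochemical assay for lipophilicity; on this read-out higher numbers stand for higher lipophilicity and lower numbers for lower lipophilicity:
compound 1, `C=C(c1cccc2ccccc12)C1CCC2(CC1)COC(Nc1cc(Cl)cc(Cl)c1)OO2`, gives 6.71
compound 2, `C=C(c1cccc2ccccc12)C1CCC2(CC1)COC(Nc1ccc(C)cc1)OO2`, gives 6.08
compound 3, `C=C(c1ccc2ccccc2c1)C1CCC2(CC1)COC(Nc1cc(Cl)cc(Cl)c1)OO2`, gives 6.71

Compound 1 and compound 3 share every atom but differ in how the cores are joined: naphthalen-2-yl in place of naphthalen-1-yl on a double-bonded chain carbon bound to a saturated ring carbon. On this read-out the two are indistinguishable, no change at the digits printed from compound 1 to compound 3 (within the scatter). Among the measured compounds shown here, the only change that registers is the one on the amine nitrogen: 4-methylphenyl in place of 3,5-dichlorophenyl on an amine nitrogen, which gave a number 0.63 log units lower from compound 1 to compound 2 (beyond the scatter).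

Compound 4, `C=C(c1ccc2ccccc2c1)C1CCC2(CC1)COC(Nc1ccc(C)cc1)OO2`, has not yet been measured. It relates to compound 3 exactly as compound 2 relates to compound 1: 4-methylphenyl in place of 3,5-dichlorophenyl on an amine nitrogen. The place of the change is described in the same words for both pairs, so it is the same change made on the other core. Since the two cores sit level, as no change at the digits printed from compound 1 to compound 3 (within the scatter) shows, the step is expected to repeat: a number 0.63 log units lower from compound 3 to compound 4 (beyond the scatter) is the estimated move, resting on a number 0.63 log units lower from compound 1 to compound 2 (beyond the scatter). Compound 4 is therefore estimated at 6.08, with a range from 5.75 to 6.4.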

Compound 4, partition coefficient: 6.08
The estimate for compound 4 equals the measured number at the digits printed; low and high end bracket the measured number.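

In this assay the exchange of 3,5-dichlorophenyl for 4-methylphenyl on the amine nitrogen carried from one core to the other: a number 0.63 log units lower from compound 3 to compound 4 (beyond the scatter) stands against a number 0.63 log units lower from compound 1 to compound 2 (beyond the scatter) as the same step, and no change at the digits printed from compound 2 to compound 4 (within the scatter) leaves the two cores as level with the new group as they were with the old one. This is a single change tested on a single pair of closely related cores, so it shows that the step repeated here and does not show that it would repeat on a different core or for a different group on that nitrogen. Nothing available bears on why the step has this size or why the two cores sit level.

The compounds shown carry only 3,5-dichlorophenyl and 4-methylphenyl on the amine nitrogen, so whether the core stays without effect with a more different group there, such as a carboxylic acid or a morpholine, remains open. The exchange also alters the chlorines and the methyl together, which leaves their separate shares in the step unresolved.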